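Allyl for phenyl on the styryl-imidazoline aryl ring

The source may hold more compounds than are shown below. What is called first, only, known or untested is meant among the compounds shown, and "the series" means these compounds.

Of the compounds shown here, two that share one core have been measured in an assay on cells (kidney, strain Sprague-Dawley) for displacement of a labelled ligand from Nischarin (Rattus norvegicus), read by scintillation counting, with a stated time of 30 min; on this read-out lower numbers stand for stronger inhibition and higher numbers for weaker inhibition. Compound 1 `Clc1ccccc1/C=C/C1=NCCN1` carries a chloro on the aromatic ring, and compound 1 gives 24 nM. Compound 2 `C(=C/c1ccccc1-c1ccccc1)\C1=NCCN1` has a phenyl at that same carbon, and compound 2 gives 97.7 nM. Going by the values given here, the single step between them, a 4.1-fold higher number from compound 1 to compound 2 (0.61 log units; beyond the scatter), is the only comparison available, and it leaves compound 2 with the higher of the two numbers, that is the weaker binding of the pair.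

Compound 3 `C=CCc1ccccc1/C=C/C1=NCCN1` is not yet measured. It differs from compound 2 as follows: allyl in place of phenyl on an aromatic carbon. Among the compounds with values here, the one measured step says that going from chloro to phenyl raised the number beyond the scatter; nothing measured says how an allyl behaves here. Given that the step from compound 1 to compound 2 pointed toward a weaker result with the larger group, compound 3 is expected to land between the two, as a step of a 2.0-fold lower number from compound 2 to compound 3 (0.29 log units; within the scatter) in this assay. Compound 3 is therefore estimated at 50 nM, with a range from 15 nM to 200 nM.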

Compound 3, inhibition constant: 69.2 nM
Compound 3: middle estimate off by 1.4-fold (0.14 log units), on the low side; low and high end bracket the measured number.
By their numbers in this assay, from the lowest: compound 1; then compounds 3 and 2 (each within the scatter of the next).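

In this assay the exchange of phenyl for allyl on this aromatic carbon, ortho to a group of 7 heavy atoms, comes out as a 1.4-fold lower number from compound 2 to compound 3 (0.15 log units; within the scatter) and so does not separate the two compounds, even though the allyl has 3 heavy atoms and no ring where the phenyl has 6 heavy atoms and a six-membered aromatic ring. The allyl also stays apart from the chloro, with a 2.9-fold higher number from compound 1 to compound 3 (0.46 log units; beyond the scatter) on the same read-out, so compound 1 remains the strongest binder of the three, and the gap to compound 1 does not depend on a ring being present at this carbon. No measurement is at hand that explains why these groups give these numbers.

Still open, as far as these compounds go, is how a methyl, a fluoro or a methoxy on the same carbon would compare with the chloro, and whether plain hydrogen there would match compound 1 or the other two. An amine, a carboxylic acid or a longer chain such as butyl at this carbon also remains to be placed against these three compounds.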